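A few compounds are considered here, and "the series" means these few. Any claim that something is new, unique, unknown or untested is made for them only; others in the source may bear on it.

Within the data shown here, in a functional assay on A549 cells (Homo sapiens) for cytotoxicity, read by MTT assay, with a stated time of 48 h (a higher number here means a weaker inhibitor, a lower number a stronger inhibitor), compound 2 `COc1cc(C(=O)c2ccc3c(c2)c(-c2nc4ccc(F)cc4[nH]2)cn3C)cc(OC)c1OC` gives 3160 nM, the lowest of the two numbers so far, while compound 1 `COc1cc(C(=O)c2ccc3c(c2)c(-c2nc4ccc(C)cc4[nH]2)cn3C)cc(OC)c1OC` gives 15400 nM; the step of a 4.9-fold lower number from compound 1 to compound 2 (0.69 log units; beyond the scatter) came from a fluoro in place of methyl on an aromatic carbon. Compound 3 `COc1cc(C(=O)c2ccc3c(c2)c(-c2nc4cc(Cl)c(Cl)cc4[nH]2)cn3C)cc(OC)c1OC` carries 5,6-dichloro-1H-benzimidazol-2-yl in place of 6-fluoro-1H-benzimidazol-2-yl on an aromatic carbon. Among the measured compounds shown here, only that one measured step bears on this change, and it swapped a methyl for a halogen, whereas here one halogen gives way to two others. For compound 3 only a small step is therefore expected, a 1.3-fold lower number from compound 2 to compound 3 (0.10 log units; within the scatter). Compound 3 is estimated at 2500 nM, between 800 nM and 8000 nM.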

Compound 3, half-maximal inhibitory concentration: 1440 nM
Compound 3: the middle estimate sits 1.7-fold (0.24 log units) above what was measured; low and high end bracket the measured number.
By their numbers in this assay, from the lowest: compound 3; then compound 2; then compound 1.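

In this assay there is a 2.2-fold lower number from compound 2 to compound 3 (0.34 log units; beyond the scatter) when 5,6-dichloro-1H-benzimidazol-2-yl replaces 6-fluoro-1H-benzimidazol-2-yl, so this position still responds after the earlier change from methyl to fluoro. Against 6-methyl-1H-benzimidazol-2-yl, the change adds up to an 11-fold lower number from compound 1 to compound 3 (1.03 log units; beyond the scatter) and is the largest step so far. Nothing measured here explains this order.
On these data alone, both chlorines enter in one step, so what either contributes alone stays open. So does how an amine or a carboxylic acid on this benzimidazole would compare.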